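Branching the Amine Chain of Compound 2

A few compounds are considered here, and "the series" means these few. Any claim that something is new, unique, unknown or untested is made for them only; others in the source may bear on it.

In an assay on striatum for inhibition of 5-hydroxytryptamine receptor 4 (Cavia porcellus), read by radioligand binding (a higher number here means a weaker inhibitor, a lower number a stronger inhibitor), the measured compounds are:
compound 1 `COc1cc(N)c(Cl)cc1C(=O)NC1CCN(CC2CCN(C(=O)CCCN)CC2)CC1` gives 3.99 nM
compound 2 `COc1cc(N)c(Cl)cc1C(=O)NC1CCN(CC2CCN(CCCCN)CC2)CC1` gives 6.47 nM

Compound 2 has the higher of the two numbers, but the step of a 1.6-fold higher number from compound 1 to compound 2 (0.21 log units; within the scatter) lies within the scatter, so the two stand level. Compound 3 `COc1cc(N)c(Cl)cc1C(=O)NC1CCN(CC2CCN(CC(C)CN)CC2)CC1` differs from compound 2 by 1-(aminomethyl)ethyl in place of 3-aminopropyl on a saturated chain carbon bound to an amine nitrogen in a ring. For the measured compounds named here, no measured step rearranges this chain; the one known step, a 1.6-fold higher number from compound 1 to compound 2 (0.21 log units; within the scatter), exchanges its attachment and stays within the scatter. Compound 3 is therefore expected to show no step beyond the scatter, a 1.2-fold higher number from compound 2 to compound 3 (0.09 log units; within the scatter). Compound 3 is estimated at 8 nM, with a range from 2.5 nM to 25 nM.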

Compound 3, half-maximal inhibitory concentration: 14.3 nM
Compound 3: the middle estimate sits 1.8-fold (0.25 log units) below what was measured, and the stated range covers the measured number.
By their numbers in this assay, from the lowest: compounds 1 and 2 (each within the scatter of the next); then compound 3.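

In this assay the chain proves responsive to rearrangement alone: with the same atoms joined differently, 1-(aminomethyl)ethyl in place of 3-aminopropyl gives a 2.2-fold higher number from compound 2 to compound 3 (0.34 log units; beyond the scatter). For the compounds shown here, this is the first change at this position to pass the scatter, and 2-(aminomethyl)propyl in place of (3-aminopropyl)carbonyl gives a 3.6-fold higher number from compound 1 to compound 3 (0.55 log units; beyond the scatter), so branching separates compound 3 from both earlier compounds. Nothing available explains this step. From the compounds shown here alone, whether a longer chain or a dimethylamino group at the chain end would shift the number further remains open, as does how a branched chain would behave with the carbonyl attachment of compound 1.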